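Working notes: the step from compound 2 to compound 3

The source may report more compounds than this note shows. Statements on the series, on what has been measured and on what is new or still open speak of the compounds shown alone.

Compound 1 `COc1ccc(Br)cc1Cn1c(C(=O)NCC(C)(C)CO)cc2cc(C#N)ccc21` gives < 6 mL.min-1.g-1 (a limit)
Compound 2 `COc1ccc(C)cc1Cn1c(C(=O)NCC(C)(C)CO)cc2cc(C#N)ccc21` gives < 6 mL.min-1.g-1 (a limit)

In an in vitro ADME assay on microsomes from Gut (Homo sapiens) for metabolic stability, using NADPH (on this read-out lower numbers stand for slow clearance and higher numbers for fast clearance), compound 2 stands at < 6 mL.min-1.g-1 as a limit, not a number. Compound 3 `CCCOc1cccc(Cn2c(C(=O)NCC(C)(C)CO)cc3cc(C#N)ccc32)c1` is not yet measured, and the change is 3-propoxyphenyl in place of 2-methoxy-5-methylphenyl on a saturated chain carbon bound to an aromatic nitrogen on the shared core. Among the measured compounds shown here, the only measured step is a step that the two limits leave unreadable from compound 1 to compound 2 and it offers no size to carry over. The data so far show the limit of < 6 mL.min-1.g-1 in this assay, at which 2 of the 2 values shown sit, and nothing more. With compound 2 at < 6 mL.min-1.g-1 as a limit, only a rise could be read. The estimated step is a number no lower from compound 2 to compound 3 (the limit leaves the size open) and at most a modest rise is expected. Compound 3 is estimated at 6 mL.min-1.g-1 with an expected range from 3 mL.min-1.g-1 to 14 mL.min-1.g-1 and may again report only a limit.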

Compound 3, intrinsic clearance in microsomes: 13 mL.min-1.g-1
Beside the measured number, compound 3's estimate is 2.2-fold (0.34 log units) below it, within the range that was stated.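

In this assay, 3-propoxyphenyl in place of 2-methoxy-5-methylphenyl on a saturated chain carbon bound to an aromatic nitrogen gives an at least 2.1-fold higher number from compound 2 to compound 3 (0.33 log units; beyond the scatter), and in place of 5-bromo-2-methoxyphenyl it gives an at least 2.1-fold higher number from compound 1 to compound 3 (0.33 log units; beyond the scatter). The step between compound 1 and compound 2 cannot be read, so this is the first sign that a change at this place can lift the read-out off the limit: the limit of < 6 mL.min-1.g-1 in this assay, at which 2 of the 3 values shown sit.

This single change alters both the ring substituents and the ether chain, and the compounds shown do not separate the two. On these data alone, whether a butoxy chain, an amine or a carboxylic acid in place of the propoxy group would raise or lower clearance remains open.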